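A few compounds are considered here, and "the series" means these few. Any claim that something is new, unique, unknown or untested is made for them only; others in the source may bear on it.

Of the compounds shown here, two that share one core have been measured in a functional assay on HeLa cells (Homo sapiens) for inhibition, read by MTT assay, with a stated time of 72 h; on this read-out higher numbers stand for weaker inhibition and lower numbers for stronger inhibition. Compound 1 `COc1cc(NC(C)CCCNC(=O)NNC(=O)Nc2cccc(Cl)c2)c2ncccc2c1` gives 44000 nM in this assay. Compound 2 `COc1cc(NC(C)CCCNC(=O)NNC(=O)Nc2ccc(F)cc2)c2ncccc2c1` reaches only the limit of this assay, >= 250000 nM, so no number is known for it. The single step between them, an at least 5.6-fold higher number from compound 1 to compound 2 (0.75 log units; beyond the scatter), is thus at least a modest weakening, and compound 2 stands at the weaker end of what is shown, resting on (the limit of >= 250000 nM in this assay, at which 1 of the 2 values shown sits).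

Compound 3 `COc1cc(NC(C)CCCNC(=O)NNC(=O)Nc2ccc(C(F)(F)F)cc2)c2ncccc2c1` differs from compound 2 in one place: trifluoromethyl in place of fluoro on an aromatic carbon. Among the measured compounds shown here, no measured step exchanges fluoro for trifluoromethyl, so the only step that bears on the change, an at least 5.6-fold higher number from compound 1 to compound 2 (0.75 log units; beyond the scatter), moves between different aryl groups and speaks only indirectly. Starting from a limit, the direction of the step in this assay cannot be read from the data. Compound 3 is expected to remain weak, with the step of an at least 1.3-fold lower number from compound 2 to compound 3 (0.14 log units; that floor lies within the scatter) estimated to lie within the scatter or slightly toward stronger inhibition. Compound 3 is therefore expected to give about 180000 nM in this assay, between 50000 nM and 600000 nM, with a fair chance that only a limit is reported again.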

Compound 3, half-maximal inhibitory concentration: 15000 nM
Compound 3: the middle estimate sits 12-fold (1.08 log units) above what was measured, and the stated range ends above it.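

Exchanging fluoro for trifluoromethyl on this aromatic carbon gives an at least 16-fold lower number from compound 2 to compound 3 (1.22 log units; beyond the scatter) in this assay, a large step that shows this position is not indifferent to the group it carries. Going by these compounds, the true size of that step remains unknown, and the figure is only a floor, since the value for compound 2 is a limit of the assay: the limit of >= 250000 nM in this assay, at which 1 of the 3 values shown sits. The exchange of 3-chlorophenyl for 4-(trifluoromethyl)phenyl gives a 2.9-fold lower number from compound 1 to compound 3 (0.47 log units; beyond the scatter), so leaving 3-chlorophenyl need not weaken inhibition, as the one earlier step had suggested, and compound 3 is the strongest of the three compounds shown in this assay.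

With only fluoro and trifluoromethyl shown on this carbon, the compounds leave open what in the trifluoromethyl group matters, and a chloro, methyl, methoxy or nitrile group at the same place would be needed to separate the possibilities. They also leave open whether the 4-(trifluoromethyl)phenyl group keeps its advantage when the rest of the molecule changes, for example with a longer chain in place of the present one or with an added amine on the shared core.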